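The source may report more compounds than this note shows. Statements on the series, on what has been measured and on what is new or still open speak of the compounds shown alone.

In an ADME assay on HEp-2 cells (Homo sapiens) for cytotoxicity (a higher number here means that more compound is tolerated, a lower number that less compound is tolerated), compound 1 `C=C(C)n1c(=O)n(Cc2nc3cc(C(=N)N)ccc3n2CCC(C)C)c2ccccc21` gives 10800 nM and compound 2 `C=C(C)n1c(=O)n(Cc2nc3cc(C(C)=O)ccc3n2CCC(C)C)c2ccccc21` gives 740 nM, the lower of the two numbers. The next comparison is compound 3 `CC(=O)c1ccc2c(c1)nc(Cn1c(=O)n(C)c3ccccc31)n2CCC(C)C`, which keeps the rest of compound 2 and changes one group: methyl in place of 1-methylethenyl on an aromatic nitrogen. In words, this is methyl in place of 1-methylethenyl on an aromatic nitrogen.

For the measured compounds named here, only one measured step is available, a 15-fold lower number from compound 1 to compound 2 (1.16 log units; beyond the scatter). It is large, but it concerns a change on an aromatic carbon, so it says nothing direct about a change on the aromatic nitrogen. It shows only that one substitution on the shared core can move this assay well beyond the scatter. Going by the values given here, no measured pair tests the loss of 1-methylethenyl, so direction and size remain poorly constrained. A modest rise is the tentative expectation, since compound 2 stands at the low end of this short series at 740 nM, but a result near or under that value would not be surprising. The estimated step is a 2.7-fold higher number from compound 2 to compound 3 (0.43 log units; beyond the scatter), modest next to the one measured. For compound 3 the expected value is 2000 nM, with an estimated range of 600 nM to 8000 nM.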

Compound 3, half-maximal cytotoxic concentration: 5200 nM
The estimate for compound 3 lay 2.6-fold (0.41 log units) below the measured number; measured number inside the range.
By their numbers in this assay, from the lowest: compound 2; then compound 3; then compound 1.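

In this assay, the substituent on the aromatic nitrogen now has a measured effect of its own: methyl in place of 1-methylethenyl gives a 7.0-fold higher number from compound 2 to compound 3 (0.85 log units; beyond the scatter) and so moves the number beyond the scatter. This is the opposite direction to a 15-fold lower number from compound 1 to compound 2 (1.16 log units; beyond the scatter) on the aromatic carbon, and the step at the nitrogen is the smaller of the two, so both places on the shared core can shift tolerance in this assay. The low number of compound 2 therefore does not depend on the group on the aromatic carbon alone, since compound 3 keeps that group and still gives the higher number. Nothing measured here accounts for the rise, and this single step cannot separate the loss of the double bond from the loss of heavy atoms.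

An ethyl or 2-propyl group on the same aromatic nitrogen would help to tell those two apart, while a hydrogen there would give a reference point for the unsubstituted nitrogen. Also open, as far as these compounds go, is whether methyl at this nitrogen gives a similar step alongside the group on the aromatic carbon of compound 1, or alongside an amine or a carboxylic acid at that carbon.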